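A few compounds are considered here, and "the series" means these few. Any claim that something is new, unique, unknown or untested is made for them only; others in the source may bear on it.

The account concerns three amides sharing a common core and tested in a functional assay on the whole organism (strain albino Sprague-Dawley) with Rattus norvegicus as the target, in the maximal electroshock model; on this read-out higher numbers stand for an effect only at larger amounts of compound and lower numbers for an effect already at smaller amounts. Within the data shown here, compound 1, `COC[C@@H](N)C(=O)NCc1ccc(OCc2cccc(F)c2)cc1`, is the only member with a full result: in this assay compound 1 gives 13 mg/kg. Compound 2, `CC(C)[C@@H](N)C(=O)NCc1ccc(Cl)cc1`, carries a chloro group on the aromatic ring at the far end of the molecule, but in this assay compound 2 is recorded as "not determined" (no result reported), so it stands without a number of its own and cannot be placed against compound 1. The next member, compound 3, `CC(C)[C@@H](N)C(=O)NCc1ccc(-c2ccccc2)cc1`, has not yet been measured. It differs from compound 2 in a single place: phenyl in place of chloro on an aromatic carbon. Among the measured compounds shown here, with no result for compound 2 and no measured pair that shows this kind of change, the size and direction of the step in this assay cannot be read from the data, and a step of any size, or none beyond the usual scatter, remains possible. On the basis of compound 1 alone, compound 3 is expected to give about 30 mg/kg in this assay, with a plausible range from 10 mg/kg to 100 mg/kg.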

Compound 3, dose for half-maximal effect: 30 mg/kg
Compound 3: the middle estimate sits on the measured number at the digits printed; low and high end bracket the measured number.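

Among these compounds, compound 2 has no number in this assay to set against compound 3, so no step between them can be read. On these data alone, what phenyl in place of chloro does to the effective dose stays open. No further evidence bears on this result.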